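Aryl swap on the ring amine of compound 1

This account rests on a few compounds, and the source may have more. Where it says the series, first, only, none or still open, it means among the compounds named here.

Measured so far:
compound 1 `CCCc1nc(-c2ccccc2)c(CNCCN2CCN(c3ccccn3)CC2)o1` — 48.1%
compound 2 `CCCc1nc(-c2ccccc2)c(CNCCCN2CCN(c3cccc(C(F)(F)F)c3)CC2)o1` — 51.6%

Both measured members of the series were run in an assay on HEK293 cells for inhibition of Voltage-dependent T-type calcium channel subunit alpha-1G (Homo sapiens), read by fluorescence, tested at 10 uM; on this read-out lower numbers stand for less inhibition and higher numbers for more inhibition at the one concentration tested (going by the name of the read-out). Compound 1 gives 48.1% and is the lower of the two numbers; compound 2 sits 51.6%, a gap that lies within the scatter of repeat measurements, so the two values are read as equivalent. Within the data shown here, no step between measured compounds that differ in one place is available.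

The next compound, compound 3 `CCCc1nc(-c2ccccc2)c(CNCCN2CCN(c3ccc(C(F)(F)F)cc3)CC2)o1`, is compound 1 with one change: 4-(trifluoromethyl)phenyl in place of pyridin-2-yl on an amine nitrogen in a ring. Among the measured compounds shown here, the only comparison at hand is compound 2, which carries a trifluoromethyl-bearing phenyl on the same ring amine nitrogen, though with a different linker, and in this assay compound 2 returns 51.6%.

On that basis the step from compound 1 to compound 3 is expected to be small: the estimate for compound 3 is 52%, with a range from 36% to 68%, and the implied step a number 3.9 percentage points higher from compound 1 to compound 3 (within the scatter) is expected to stay within the scatter rather than show a real change in either direction.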

Compound 3, a percentage reported as inhibition, at one concentration (the size of the read-out at that concentration, not a potency): 58.7%
The estimate for compound 3 lay 6.7 percentage points below the measured number; measured number inside the range.
By their numbers in this assay, from the lowest: compounds 1, 2 and 3 (each within the scatter of the next, the first and the last beyond it).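

In this assay, among these compounds, 4-(trifluoromethyl)phenyl in place of pyridin-2-yl on the amine nitrogen in the ring gives a number 10.6 percentage points higher from compound 1 to compound 3 (beyond the scatter), the first step that can be read at a single place, and it shows that the group at this position can shift the read-out by a modest amount. The change touches several features at once: a six-membered aromatic ring with 1 hetero atom gives way to a ring of carbon only, the hydrogen-bond acceptor of the leaving group goes, and the entering group holds more heavy atoms than the leaving group. Nothing at hand separates these features or ties the step to any one of them.

The compounds shown leave open whether the step follows the loss of the ring nitrogen or the arrival of the trifluoromethyl group, a question that plain phenyl, pyridin-3-yl or 4-chlorophenyl on the same nitrogen would address. From the compounds shown here alone, compound 2 differs from compound 3 in both the linker and the place of the trifluoromethyl group, so the contribution of a longer chain also stays open.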